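The source may hold more compounds than are shown below. What is called first, only, known or untested is meant among the compounds shown, and "the series" means these compounds.

Working notes on the series, all values from an in vitro assay on CHO cells for displacement of a labelled ligand from Bombesin receptor subtype-3 (Homo sapiens), read by scintillation counting, with a stated time of 2 h; a higher number here means a weaker inhibitor, a lower number a stronger inhibitor. Compound 1 `CCC(C)(C)Cc1c[nH]c(CCc2ccc(-c3cccc(C#N)n3)cc2)n1` gives 140 nM, and compound 2 `CCC(C)(C)Cc1c[nH]c(CCc2ccc(-c3csnn3)cc2)n1` gives 45 nM. Going by the values given here, compound 1 therefore stands as the higher of the two numbers measured so far, with compound 2 nearest to it: a 3.1-fold lower number from compound 1 to compound 2 (0.49 log units; beyond the scatter). Compound 3 `CCC(C)(C)Cc1c[nH]c(CCc2ccc(N3CCCCC3)cc2)n1` is not yet measured. It differs from compound 1 in a single place: piperidin-1-yl in place of 6-cyanopyridin-2-yl on an aromatic carbon. Among the compounds with values here, the only measured step that bears on this change is the one from compound 1 to compound 2, which also removed the 6-cyanopyridin-2-yl group but brought in an aromatic heterocycle rather than a non-aromatic piperidin-1-yl ring, so it is only a loose guide. A modest step in either direction, or none beyond the scatter, is expected. Compound 3 is estimated at 120 nM, within 40 nM to 400 nM, which means an expected step of a 1.2-fold lower number from compound 1 to compound 3 (0.07 log units; within the scatter).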

Compound 3, half-maximal inhibitory concentration: 28 nM
The estimate for compound 3 lay 4.3-fold (0.63 log units) above the measured number; measured number below the stated range.
By their numbers in this assay, from the lowest: compounds 3 and 2 (each within the scatter of the next); then compound 1.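

In this assay, the aromatic carbon para to a large group accepts a non-aromatic ring as well as an aromatic one: piperidin-1-yl in place of 6-cyanopyridin-2-yl gives a 5.0-fold lower number from compound 1 to compound 3 (0.70 log units; beyond the scatter). Piperidin-1-yl in place of 1,2,3-thiadiazol-4-yl gives a 1.6-fold lower number from compound 2 to compound 3 (0.21 log units; within the scatter), so these two groups cannot be separated at this position, and among the three compounds only the 6-cyanopyridin-2-yl group stands apart. No measurement at hand accounts for this difference.

As far as these compounds go, it remains open whether the nitrile or the pyridine ring of compound 1 goes with its higher number, a question that a plain pyridin-2-yl group would address. Also open, from the compounds shown here alone, is whether morpholin-4-yl or an open-chain dimethylamino group would stay level with piperidin-1-yl.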